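A few compounds are considered here, and "the series" means these few. Any claim that something is new, unique, unknown or untested is made for them only; others in the source may bear on it.

Measured compounds:
Compound 1, `O=C(O)Cc1sc(C(c2ccccc2)c2ccccc2)nc1-c1ccccc1`: 80%
Compound 2, `O=C(O)Cc1sc(C(c2ccc(F)cc2)c2ccc(F)cc2)nc1-c1ccnc(F)c1`: 80%

Both compounds were tested in an in vitro functional assay on HEK285-7 cells for antagonist activity at prostaglandin D2 receptor 2 (Homo sapiens), read by BRET and beta-arrestin recruitment; a higher number here means a larger maximal response, a lower number a smaller maximal response. Compound 1 and compound 2 share the same core, and in this assay compound 2 stands level with compound 1 at the digits shown; the two values lie within the usual scatter of each other, so no difference between them can be claimed.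

Compound 3, `N#Cc1ccc(-c2nc(C(c3ccc(F)cc3)c3ccc(F)cc3)sc2CC(=O)O)cc1`, has not yet been measured. It differs from compound 2 in one place: 4-cyanophenyl in place of 2-fluoropyridin-4-yl on an aromatic carbon. Going by the values given here, no step between two measured compounds exists that makes the same kind of exchange, so there is nothing in the data to set a direction for it. The two measured values sit together, and the exchange leaves the core and the carboxymethyl group untouched, so for compound 3 the change from compound 2 is expected to be small, a number 2 percentage points lower from compound 2 to compound 3 (within the scatter), within the scatter. Compound 3 is therefore estimated to reach 78% in this assay, with a range from 60% to 95%.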

Compound 3, largest response reached (reported as efficacy), in percent of the reference or control that the assay uses: 30%
Compound 3: middle estimate off by 48 percentage points, on the high side; the measured number lies below the stated range.
By their numbers in this assay, from the lowest: compound 3; then compounds 1 and 2 (each within the scatter of the next).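

In this assay, the group on this aromatic carbon, next to the ring nitrogen, has a large effect on the maximal response: 4-cyanophenyl in place of 2-fluoropyridin-4-yl gives a number 50 percentage points lower from compound 2 to compound 3 (beyond the scatter), a step well beyond the scatter. Compound 2 and compound 3 differ only in this group, so the whole step belongs to this one exchange, and the position cannot be treated as one that tolerates any aromatic ring. Nothing measured here bears on the reason for the step.

The exchange removes the ring nitrogen and the fluorine and adds a nitrile all at once, so the compounds shown do not tell which of these parts matters. Going by these compounds, it remains open whether a pyridin-4-yl or a 4-fluorophenyl group on this carbon would give a response nearer that of compound 2 or that of compound 3.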